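Swapping 2,4-dichlorophenyl for 4-fluorophenyl: expected recovery

The source may report more compounds than this note shows. Statements on the series, on what has been measured and on what is new or still open speak of the compounds shown alone.

In a functional assay on A549 cells (Homo sapiens) for antiproliferative activity, read by MTT assay, with a stated time of 72 h (on this read-out higher numbers stand for weaker inhibition and lower numbers for stronger inhibition), compound 1 `COc1ccc(-c2ccc3ncn(-c4cc(OC)c(OC)c(OC)c4)c3c2)cc1F` gives 1430 nM as a measured value and compound 2 `COc1cc(-n2cnc3ccc(-c4ccc(C(F)(F)F)cc4)cc32)cc(OC)c1OC` gives 3390 nM as another. Compound 3 `COc1cc(-n2cnc3ccc(-c4ccc(Cl)cc4Cl)cc32)cc(OC)c1OC` gives > 10000 nM as a limit and not a number, which leaves it at the weak end of the three.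

Compound 4 `COc1cc(-n2cnc3ccc(-c4ccc(F)cc4)cc32)cc(OC)c1OC` is unmeasured and differs from compound 3 as follows: 4-fluorophenyl in place of 2,4-dichlorophenyl on an aromatic carbon with 4-fluorophenyl in place of 2,4-dichlorophenyl on an aromatic carbon. Three measured steps at this same place bear on it. The change to 2,4-dichlorophenyl gave an at least 6.9-fold higher number from compound 1 to compound 3 (0.84 log units; beyond the scatter) and an at least 2.9-fold higher number from compound 2 to compound 3 (0.46 log units; beyond the scatter) while the exchange of the other two groups gave a 2.4-fold higher number from compound 1 to compound 2 (0.37 log units; beyond the scatter) as the remaining step. With 2,4-dichlorophenyl gone, compound 4 is expected to return toward compound 1 and compound 2 with a lower number than the limit of compound 3. The estimated step is an at least 3.3-fold lower number from compound 3 to compound 4 (0.52 log units; beyond the scatter) and stays uncertain since it starts from a limit. Compound 4 is estimated at 3000 nM (expected range 1000 nM to 9000 nM).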

Compound 4, half-maximal inhibitory concentration: 6740 nM
Compound 4: the middle estimate sits 2.2-fold (0.35 log units) below what was measured, within the range that was stated.
By their numbers in this assay, from the lowest: compound 1; then compounds 2 and 4 (each within the scatter of the next). At a limit, above all of these: compound 3.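

In this assay, 4-fluorophenyl does not match the 3-fluoro-4-methoxyphenyl of compound 1, the change giving a 4.7-fold higher number from compound 1 to compound 4 (0.67 log units; beyond the scatter). Fluoro in place of trifluoromethyl gives a 2.0-fold higher number from compound 2 to compound 4 (0.30 log units; within the scatter), so these two substituents are not told apart on this read-out. Leaving 2,4-dichlorophenyl for 4-fluorophenyl gives an at least 1.4-fold lower number from compound 3 to compound 4 (0.17 log units; that floor lies within the scatter), so no clear recovery can be claimed from a step that starts at the limit of compound 3: the limit of > 10000 nM in this assay, at which 1 of the 4 values shown sits.

As far as these compounds go, it remains open whether the methoxy group alone carries the lower number of compound 1, a question that a 4-methoxyphenyl compound would settle. Also open, from the compounds shown here alone, is how an amine or a carboxylic acid on this phenyl ring would read in this assay.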